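This account rests on a few compounds, and the source may have more. Where it says the series, first, only, none or still open, it means among the compounds named here.

Of the compounds shown here, three built on one shared core have been tested in a functional assay on U-937 cells (Homo sapiens) for cytotoxicity, read by MTT assay, with a stated time of 24 h; a higher number here means a weaker inhibitor, a lower number a stronger inhibitor. Compound 1, `Nc1nn(Cc2cn(CCC(F)(F)C(F)(F)C(F)(F)C(F)(F)C(F)(F)C(F)(F)F)nn2)c2nc(-c3ccccc3)cc(C(F)(F)F)c12`, gives 98.2 ug/mL. Compound 2, `CCCCCCCCCCn1cc(Cn2nc(N)c3c(C(F)(F)F)cc(-c4ccccc4)nc32)nn1`, gives 27.1 ug/mL. Compound 3, `Nc1nn(Cc2cn(-c3cccc(Cl)c3)nn2)c2nc(-c3ccccc3)cc(C(F)(F)F)c12`, gives 32.4 ug/mL, which places it second highest of the three numbers: its nearest neighbour is compound 2, within the scatter of it, and its furthest is compound 1, whose number lies beyond the scatter from it. Among the measured compounds shown here, the only change of a single group among the measured compounds is a 1.2-fold higher number from compound 2 to compound 3 (0.08 log units; within the scatter), a swap of a long chain for a ring on an aromatic nitrogen that left the number essentially where it was.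

Compound 4, `Nc1nn(Cc2cn(-c3ccc(O)c([N+](=O)[O-])c3)nn2)c2nc(-c3ccccc3)cc(C(F)(F)F)c12`, differs from compound 3 as follows: 4-hydroxy-3-nitrophenyl in place of 3-chlorophenyl on an aromatic nitrogen. For the measured compounds named here, no measured step exchanges one ring for another at this aromatic nitrogen, so the only guidance is that the one change made there so far, from a chain to a ring, stayed within the scatter. On that slim basis the step of a 1.1-fold higher number from compound 3 to compound 4 (0.03 log units; within the scatter) is expected to be small, with no clear direction beyond the scatter. Compound 4 is therefore estimated at 35 ug/mL, with a likely range from 14 ug/mL to 90 ug/mL.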

Compound 4, half-maximal inhibitory concentration: 41.3 ug/mL
The estimate for compound 4 lay 1.2-fold (0.07 log units) below the measured number, within the range that was stated.
By their numbers in this assay, from the lowest: compounds 2, 3 and 4 (each within the scatter of the next); then compound 1.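

In this assay, among the compounds shown here, this is the first exchange of one ring for another on this aromatic nitrogen, and it gives a 1.3-fold higher number from compound 3 to compound 4 (0.11 log units; within the scatter) even though 4-hydroxy-3-nitrophenyl brings a hydrogen-bond donor and hydrogen-bond acceptors that 3-chlorophenyl does not have. Measured against the decyl chain, the same group gives a 1.5-fold higher number from compound 2 to compound 4 (0.18 log units; within the scatter), so decyl, 3-chlorophenyl and 4-hydroxy-3-nitrophenyl cannot be told apart at this position, and only compound 1, with its fluorinated chain, stands apart at 98.2 ug/mL as the exception to this flat picture. Nothing available here explains why such different groups give numbers within the scatter of one another.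

The compounds shown leave open whether the hydroxy and nitro groups would matter on their own, as they enter together here, and whether a phenyl ring with no substituent, or one carrying an amine or a carboxylic acid, would stay within this same scatter. They also leave open whether the separate number of compound 1 comes from the fluorines on its chain, which a plain octyl chain would help to test.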